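This account rests on a few compounds, and the source may have more. Where it says the series, first, only, none or still open, it means among the compounds named here.

In a functional assay on HCT-116 cells (Homo sapiens) for antiproliferative activity, read by CCK-8 assay, with a stated time of 72 h (on this read-out lower numbers stand for stronger inhibition and higher numbers for weaker inhibition), compound 1 `CC1=NN(c2ccc(C)cc2)C(=O)C12C=CC(=O)C=C2c1ccccc1` gives 16500 nM and stands second highest of the three numbers; compound 3 `CC1=NN(c2ccccc2)C(=O)C12C=CC(=O)C=C2c1ccc(C)cc1` is nearest with 27100 nM, and compound 2 `CC1=NN(c2ccc(C)cc2)C(=O)C12C=CC(=O)C=C2c1cccc(C)c1` is furthest with 8340 nM. Going by the values given here, the only single-place step is a 2.0-fold lower number from compound 1 to compound 2 (0.30 log units; within the scatter), a methyl in place of hydrogen on an aromatic carbon. Compound 4 `CC1=NN(c2cccc(Cl)c2)C(=O)C12C=CC(=O)C=C2c1ccccc1` changes compound 1 at another spot: 3-chlorophenyl in place of 4-methylphenyl on an amide-type nitrogen in a ring. Among the compounds with values here, no measured step alters the group on the amide-type nitrogen, and compound 3 differs from compound 1 in two places, so its value is only a comparison. The change is therefore expected to give no step beyond the scatter in this assay, as a 1.1-fold lower number from compound 1 to compound 4 (0.04 log units; within the scatter). Compound 4 is estimated at 15000 nM, between 6000 nM and 40000 nM.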

Compound 4, half-maximal inhibitory concentration: 7000 nM
Compound 4: middle estimate off by 2.1-fold (0.33 log units), on the high side; the range from low to high includes it.
By their numbers in this assay, from the lowest: compounds 4, 2, 1 and 3 (each within the scatter of the next, the first and the last beyond it).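

In this assay, going by these compounds alone, the group on the amide-type nitrogen proves able to shift the number: 3-chlorophenyl in place of 4-methylphenyl gives a 2.4-fold lower number from compound 1 to compound 4 (0.37 log units; beyond the scatter) and is the first single-place step beyond the scatter here, though a modest one. Within the data shown here, no earlier single-place step touched this position. No evidence at hand bears on this result.

On these data alone, whether the step belongs to the chlorine or to where it sits stays open, since the swap changes both at once. Also open, as far as these compounds go, is how an amine or a carboxylic acid on this phenyl ring would read.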